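This account rests on a few compounds, and the source may have more. Where it says the series, first, only, none or still open, it means among the compounds named here.

In an ADME assay on HEK293 cells (Homo sapiens) for cytotoxicity, read by MTT assay, with a stated time of 48 h (a lower number here means a stronger inhibitor, a higher number a weaker inhibitor), three compounds sharing one core have been measured. Compound 1 `O=C1/C(=C\c2ccccc2)S/C(=N/c2ccccc2)N1Cc1ccncc1` gives 64700 nM. Compound 2 `O=C1/C(=C\c2ccc(O)cc2)S/C(=N/c2ccccc2)N1Cc1ccncc1`, with a hydroxy group added, gives 142000 nM. Compound 3 `O=C1/C(=C\c2ccc([N+](=O)[O-])cc2)S/C(=N/c2ccccc2)N1Cc1ccncc1`, with a nitro group instead, gives 250000 nM. Compound 3 stands clearly apart from one of its neighbours but not from the other, as the steps are a 3.9-fold higher number from compound 1 to compound 3 (0.59 log units; beyond the scatter) and a 1.8-fold higher number from compound 2 to compound 3 (0.25 log units; within the scatter).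

The next structure, compound 4 `O=C1/C(=C\c2ccc(O)c(O)c2)S/C(=N/c2ccccc2)N1Cc1ccncc1`, brings 3,4-dihydroxyphenyl in place of 4-nitrophenyl on a double-bonded chain carbon bound to a double-bonded ring carbon. The nearest guide is compound 2, which also carries a hydroxy group and gives 142000 nM. Adding that group gave a 2.2-fold higher number from compound 1 to compound 2 (0.34 log units; beyond the scatter), a modest step. Going by the values given here, no measured compound carries two hydroxy groups, so the effect of the second one remains open. The expected change is a 1.9-fold lower number from compound 3 to compound 4 (0.28 log units; within the scatter), a small move towards a lower number that may not clear the scatter. For compound 4 the estimated value is 130000 nM, with an expected range from 55000 nM to 280000 nM.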

Compound 4, half-maximal inhibitory concentration: 230000 nM
For compound 4 the middle estimate is 1.8-fold (0.25 log units) below the measured one; low and high end bracket the measured number.
By their numbers in this assay, from the lowest: compound 1; then compounds 2, 4 and 3 (each within the scatter of the next).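

In this assay, the place on a double-bonded chain carbon bound to a double-bonded ring carbon does not separate 4-nitrophenyl from 3,4-dihydroxyphenyl (a 1.1-fold lower number from compound 3 to compound 4 (0.04 log units; within the scatter)). A second hydroxy group on the aromatic ring also leaves no readable difference (a 1.6-fold higher number from compound 2 to compound 4 (0.21 log units; within the scatter)), whereas the plain phenyl of compound 1 remains clearly apart from the dihydroxy ring (a 3.6-fold higher number from compound 1 to compound 4 (0.55 log units; beyond the scatter)). Across the compounds shown, the three substituted rings therefore form one group within the scatter of each other, and each has a higher number than the unsubstituted phenyl ring.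

No supporting evidence is available to explain this pattern. From the compounds shown here alone, it remains open whether an amine, a carboxylic acid or a methoxy group on this aromatic ring would stay with that group or fall closer to compound 1.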